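Fluoro for Chloro on the Aryl Ring of Compound 1

This account rests on a few compounds, and the source may have more. Where it says the series, first, only, none or still open, it means among the compounds named here.

Compound 1 `OC[C@@H]1C[C@H](CO)[C@@H]2C(c3ccc(Cl)cc3)=NO[C@H]12` carries a chloro on its aromatic ring. In a functional assay on PC-3 cells (Homo sapiens) for cytotoxicity, read by MTT assay, with a stated time of 48 h (a higher number here means a weaker inhibitor, a lower number a stronger inhibitor), compound 1 gives only a limit, > 50 ug/mL, and not a number. Compound 2 `Cc1ccc(C2=NO[C@@H]3[C@H](CO)C[C@H](CO)[C@H]23)cc1` carries a methyl in the same place, and in this assay compound 2 gives 28 ug/mL. Among the measured compounds shown here, the single measured step, an at least 1.7-fold lower number from compound 1 to compound 2 (0.25 log units; that floor lies within the scatter), reaches only a floor because compound 1 sits at the limit of > 50 ug/mL in this assay, at which 1 of the 2 values shown sits. Compound 3 `OC[C@@H]1C[C@H](CO)[C@@H]2C(c3ccc(F)cc3)=NO[C@H]12` is the unmeasured partner: fluoro in place of chloro on an aromatic carbon. For the measured compounds named here, no measured step exchanges one halogen for another; the methyl step is the only indirect guide, and its floor lies within the scatter. The step of a number no higher from compound 1 to compound 3 (the limit leaves the size open) is therefore expected to be small, possibly none beyond the scatter. Compound 3 is estimated at 50 ug/mL, within 25 ug/mL to 100 ug/mL, with a fair chance that the assay again reports only a limit.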

Compound 3, half-maximal inhibitory concentration: > 50 ug/mL
Compound 3 ended at the assay's limit; the forecaster's own chance of this, stated with the estimate: 55%; the middle value sits exactly at the limit.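

In this assay compound 3 gives > 50 ug/mL, which is a limit and not a number. The step between the two halogens cannot be read, and any difference between chloro and fluoro at this aromatic carbon stays hidden because both compounds rest on the same limit: the limit of > 50 ug/mL in this assay, at which 2 of the 3 values shown sit. Fluoro in place of methyl gives an at least 1.7-fold higher number from compound 2 to compound 3 (0.25 log units; that floor lies within the scatter), so this second comparison with methyl again reaches only a floor and shows no difference beyond the scatter.

On these data alone, whether an amine, a methoxy group or a carboxylic acid on this aromatic carbon would give a number clearly lower than that of compound 2 remains open. So does the true size of the values of compound 1 and compound 3, which lie somewhere beyond the limit.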